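The source may report more compounds than this note shows. Statements on the series, on what has been measured and on what is new or still open speak of the compounds shown alone.

Measured compounds:
- compound 1, `CN1CCC[C@H]1[C@@H]1COc2cc([N+](=O)[O-])ccc2O1`: 15000 nM
- compound 2, `CN1CCC[C@H]1[C@H]1COc2cc([N+](=O)[O-])ccc2O1`: 4800 nM

Both were tested in an assay on membranes from HEK293 cells for displacement of a labelled ligand from Neuronal acetylcholine receptor; alpha3/beta4 (Homo sapiens), with a stated time of 5 min; a higher number here means a weaker inhibitor, a lower number a stronger inhibitor. Compound 1 has the same atoms and bonds as compound 2, and the two differ only in the configuration drawn at one saturated ring carbon. In this assay compound 1 gives 15000 nM, while compound 2 gives 4800 nM. The step of a 3.1-fold lower number from compound 1 to compound 2 (0.49 log units; beyond the scatter) lies beyond the usual scatter and is explained only by the fact that compounds 1 and 2 differ only in the configuration as drawn. Compound 2 therefore stands lowest of the two values shown.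

Compound 3, `CN1CCC[C@H]1[C@H]1COc2cc(-c3ccccc3)ccc2O1`, has not yet been measured. It differs from compound 2 by phenyl in place of nitro on an aromatic carbon of the shared core. Within the data shown here, neither measured step touches this position, since the only step recorded concerns configuration alone, so no measured step bears directly on the change. Lacking such guidance, the step of a 1.3-fold higher number from compound 2 to compound 3 (0.10 log units; within the scatter) from compound 2 to compound 3 is an estimate with a wide range. For compound 3 the expected value in this assay is 6000 nM, estimated to fall between 1500 nM and 25000 nM.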

Compound 3, inhibition constant: 5800 nM
Beside the measured number, compound 3's estimate is 1.0-fold (0.01 log units) above it, and the stated range covers the measured number.
By their numbers in this assay, from the lowest: compounds 2 and 3 (each within the scatter of the next); then compound 1.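

On this aromatic carbon, placing phenyl where nitro stood gives, in this assay, a 1.2-fold higher number from compound 2 to compound 3 (0.08 log units; within the scatter), so the assay does not separate the two compounds. Among these compounds, this is the first information about this position, and the exchange is not a small one: nitro, a group with hydrogen-bond acceptors and no ring, leaves, and phenyl, a six-membered aromatic ring of carbon only with more heavy atoms and no hydrogen-bond acceptors, enters, yet the number stays within the scatter. The evidence at hand concerns only configuration and does not bear on this exchange, so the result comes without an explanation.

From the compounds shown here alone, it remains open whether an amine or a carboxylic acid on this same aromatic carbon would give a number set apart from those of compound 2 and compound 3. The compounds shown also hold phenyl in one configuration only, so it remains open whether the step seen between the two nitro compounds would carry over to the phenyl series.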